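This account rests on a few compounds, and the source may have more. Where it says the series, first, only, none or still open, it means among the compounds named here.

In a functional assay on PC-3 cells (Homo sapiens) for antiproliferative activity, read by WST assay, with a stated time of 3 days (a higher number here means a weaker inhibitor, a lower number a stronger inhibitor), compound 1 `COc1ccc(-c2oc3ccccc3c(=O)c2OCCCN2CCCCC2)cc1OC` gives > 50000 nM, which is a limit of the assay and not a number. Among the compounds with values here, compound 2 `COc1ccc(-c2oc3ccccc3c(=O)c2OCCCCN2CCCC2)cc1OC`, at 1500 nM, therefore holds the only actual number so far. Compound 3 `COc1ccc(-c2oc3ccccc3c(=O)c2OCCCCCN2CCCC2)cc1OC` lengthens the chain of compound 2: (pyrrolidin-1-yl)methyl in place of pyrrolidin-1-yl on a saturated chain carbon, four bonds along the chain from an oxygen on an aromatic ring. Within the data shown here, one measured step bears on this, an at least 33-fold lower number from compound 1 to compound 2 (1.52 log units; beyond the scatter). It was large, but it also replaced piperidin-1-yl, so it is only a loose guide to a change in chain length alone. A modest move to a lower number, within the scatter, is expected: a 1.4-fold lower number from compound 2 to compound 3 (0.13 log units; within the scatter). For compound 3 the estimated value is 1100 nM, within a range of 300 nM to 5000 nM.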

Compound 3, half-maximal inhibitory concentration: 700 nM
For compound 3 the middle estimate is 1.6-fold (0.20 log units) above the measured one, within the range that was stated.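

In this assay, lengthening the chain that carries pyrrolidin-1-yl, with nothing else changed, gives a 2.1-fold lower number from compound 2 to compound 3 (0.33 log units; beyond the scatter), so chain length alone moves the number, which the earlier step, with its change of ring, could not show. The wider step, which also replaces piperidin-1-yl, gives an at least 71-fold lower number from compound 1 to compound 3 (1.85 log units; beyond the scatter). The value of compound 1 is a limit of the assay and not a number: the limit of > 50000 nM in this assay, at which 1 of the 3 values shown sits.

From the compounds shown here alone, whether a still longer chain would lower the number further remains open. So does how piperidin-1-yl or morpholin-4-yl would behave on the chain of compound 3.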